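Vero Cell Tolerance for Compound 4, Estimated from Compound 1

The source may report more compounds than this note shows. Statements on the series, on what has been measured and on what is new or still open speak of the compounds shown alone.

Compound 1, `COC(=O)c1cc(-c2cccc(NC(=O)c3ccc(/C=C/C(=O)c4ccc(OC)cc4)cc3)c2)on1`, gives > 10 ug/mL in an ADME assay on Vero cells (Chlorocebus sabaeus) for cytotoxicity, read by MTT assay, with a stated time of 72 h; a higher number here means that more compound is tolerated, a lower number that less compound is tolerated.
Compound 3, `COC(=O)c1cc(-c2ccc(NC(=O)c3ccc(/C=C/C(=O)c4ccc(Cl)cc4)cc3)cc2)on1`, gives > 80 ug/mL in this assay.
Compound 2, `CCOC(=O)c1cc(-c2cccc(NC(=O)c3cccc(C(F)(F)F)c3)c2)on1`, is recorded as "not determined" (no result reported) in this assay.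

The figure for compound 1 is a limit of the assay and not a number, as shown by the limit of > 10 ug/mL in this assay, at which 1 of the 3 values shown sits. The figure for compound 3 is likewise a limit, as shown by the limit of > 80 ug/mL in this assay, at which 1 of the 3 values shown sits. Compound 1 therefore stands with only a limit among the three entries, one further entry also being a limit and one carrying no number at all.

Compound 4, `COC(=O)c1cc(-c2cccc(NC(=O)c3ccc(/C=C/C(=O)c4ccc(Cl)cc4Cl)cc3)c2)on1`, differs from compound 1 by 2,4-dichlorophenyl in place of 4-methoxyphenyl on a carbonyl carbon. For the measured compounds named here, no step between two measured compounds is available, so there is nothing here to set the size of this change against. The step is expected to stay within the scatter of repeated measurements, as a step that the limit leaves unreadable from compound 1 to compound 4. Compound 4 is estimated at 20 ug/mL, with a range from 8 ug/mL to 80 ug/mL, and the result may again be reported only as a limit.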

Compound 4, half-maximal cytotoxic concentration: > 40 ug/mL
Compound 4: only a limit was reported (the forecaster's own chance of this, stated with the estimate: 65%); middle value at least 2.0-fold (0.30 log units) from the limit.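

Compound 1 and compound 4 are both recorded only as limits in this assay, and no step can be read between them. The compounds shown leave open whether 2,4-dichlorophenyl in place of 4-methoxyphenyl on a carbonyl carbon changes the tolerated concentration at all.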